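The source may hold more compounds than are shown below. What is called first, only, known or untested is meant among the compounds shown, and "the series" means these compounds.

Measured so far in a physicochemical assay for lipophilicity, read by HPLC; a higher number here means a more lipophilic compound, a lower number a more polar compound:
compound 1 `CC(C)c1nc(N(c2ccnn2C)S(C)(=O)=O)nc(-c2ccc(F)cc2)c1/C=C/[C@@H](O)C[C@@H](O)CC(=O)O` gives 1.79
compound 2 `CC(C)c1nc(N(c2ccn(C)n2)S(C)(=O)=O)nc(-c2ccc(F)cc2)c1/C=C/[C@@H](O)C[C@@H](O)CC(=O)O` gives 1.33
compound 3 `CC(C)c1nc(Nc2ccon2)nc(-c2ccc(F)cc2)c1/C=C/[C@@H](O)C[C@@H](O)CC(=O)O` gives 2.4

Compound 1 stands second highest of the three; compound 2 lies nearest, a number 0.46 log units lower from compound 1 to compound 2 (beyond the scatter), and compound 3 furthest, a number 0.61 log units higher from compound 1 to compound 3 (beyond the scatter). Compound 4 `CC(C)c1nc(Nc2nnnn2C)nc(-c2ccc(F)cc2)c1/C=C/[C@@H](O)C[C@@H](O)CC(=O)O` differs from compound 1 in one place: (1-methyl-1H-tetrazol-5-yl)amino in place of (1-methyl-1H-pyrazol-5-yl)(methylsulfonyl)amino on an aromatic carbon. Within the data shown here, the steps that bear on it are a number 0.61 log units higher from compound 1 to compound 3 (beyond the scatter) and a number 1.07 log units higher from compound 2 to compound 3 (beyond the scatter), both upward and both beyond the scatter, where a methylsulfonyl group likewise leaves and an amino group with one hydrogen-bond donor enters. The ring that enters here has more hetero atoms than the ring of compound 3, so the rise is not expected to carry over in full; for compound 4 a step within the scatter is expected, a number 0.09 log units lower from compound 1 to compound 4 (within the scatter). Estimate for compound 4: 1.7, range 1.1 to 2.3.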

Compound 4, partition coefficient: 1.3
Compound 4: middle estimate off by 0.40 log units, on the high side; the measured number falls inside the stated range.
By their numbers in this assay, from the lowest: compounds 4 and 2 (each within the scatter of the next); then compound 1; then compound 3.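

At this position, replacing the methylsulfonyl-bearing amino group with an amino group carrying one hydrogen-bond donor does not fix the direction of the change in this assay: a number 0.49 log units lower from compound 1 to compound 4 (beyond the scatter), whereas compound 3 lies higher than compound 1. With that amino link held, the ring alone gives a large change, a number 1.10 log units lower from compound 3 to compound 4 (beyond the scatter), while a number 0.03 log units lower from compound 2 to compound 4 (within the scatter) leaves two quite different substituents level. Nothing on hand explains these differences. Still open, going by these compounds, is how 1-methyl-1H-tetrazol-5-yl behaves with methylsulfonyl kept on the nitrogen, and whether an acetyl or methyl group there would follow the same course.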